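A few compounds are considered here, and "the series" means these few. Any claim that something is new, unique, unknown or untested is made for them only; others in the source may bear on it.

Measured compounds in a functional assay on NUGC-3 cells (Homo sapiens) for inhibition, read by sulforhodamine B assay, with a stated time of 48 h; on this read-out higher numbers stand for weaker inhibition of growth and lower numbers for stronger inhibition of growth:

Compound 1, `O=C(Nc1cccc(C(F)(F)F)c1)c1nccc2ccccc12`: compound 1 gives > 10000 nM, a limit of the assay.
Compound 2, `COc1ccccc1NC(=O)C1NCCc2ccccc21`: compound 2 gives > 10000 nM, a limit of the assay.
Compound 3, `O=C(Nc1ccccc1C(F)(F)F)c1nccc2ccccc12`: compound 3 gives > 10000 nM, a limit of the assay.

Of the three measured compounds, none returns a number in this assay; all three sit at the limit of > 10000 nM in this assay, at which 3 of the 3 values shown sit. Compound 2 therefore stands nowhere in particular among them: its result is only a limit, and the two other results are the same limit, so no ordering of the three can be read from the data.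

The unmeasured compound 4, `COc1ccccc1NC(=O)C1c2ccccc2CCN1C(=O)c1ccc(Cl)cc1`, is built from compound 2 by one change, (4-chlorophenyl)carbonyl in place of hydrogen on an amine nitrogen in a ring — in words, (4-chlorophenyl)carbonyl in place of hydrogen on an amine nitrogen in a ring. Going by the values given here, no measured step of this kind is available, and the three results give no direction to lean on. The expected step from compound 2 to compound 4 in this assay, an at least 1.2-fold lower number from compound 2 to compound 4 (0.09 log units; that floor lies within the scatter), is thus set near zero, within the scatter, with a wide range on either side. The estimate for compound 4 in this assay is 8000 nM, between 1500 nM and 30000 nM, with a fair chance that only a limit is reported again.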

Compound 4, concentration for 50% growth inhibition: 1590 nM
Beside the measured number, compound 4's estimate is 5.0-fold (0.70 log units) above it; the range from low to high includes it.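

In this assay, the amine nitrogen in the ring, next to the ring atom that bears a large group, is the one place where the compounds shown give a change that brings a real number rather than a limit. Putting (4-chlorophenyl)carbonyl in place of hydrogen there gives an at least 6.2-fold lower number from compound 2 to compound 4 (0.79 log units; beyond the scatter), which shows that this nitrogen can carry a large aromatic acyl group and that the change moves the read-out beyond the scatter. That step is only a floor and not a full size, because the starting point of the step is a limit, like most of the results shown: the limit of > 10000 nM in this assay, at which 3 of the 4 values shown sit.

The compounds shown leave open whether the step belongs to the carbonyl, the aromatic ring or the chlorine, and whether a benzoyl group without chlorine, an acetyl group or a simple methyl group on the same nitrogen would also bring a number. They also leave open whether fluorine or a methoxy group could stand in for the chlorine, and how far the true step reaches beyond its floor.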